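A few compounds are considered here, and "the series" means these few. Any claim that something is new, unique, unknown or untested is made for them only; others in the source may bear on it.

In a functional assay on MCF7 cells (Homo sapiens) for antiproliferative activity, read by MTT assay, with a stated time of 24 h; on this read-out lower numbers stand for stronger inhibition and higher numbers for weaker inhibition:
- Compound 1 `CCn1c(C(=O)NCCCO)ccc1C(CC)(CC)c1ccc(OCS(=O)(=O)c2ccccc2)c(C)c1`: 42000 nM
- Compound 2 `CCn1c(C(=O)N[C@H](CO)CCO)ccc1C(CC)(CC)c1ccc(OCS(=O)(=O)c2ccccc2)c(C)c1`: 28500 nM

Compound 2 stands within the scatter of compound 1. Compound 3 `CCn1c(C(=O)N[C@@H](C)C(=O)O)ccc1C(CC)(CC)c1ccc(OCS(=O)(=O)c2ccccc2)c(C)c1` carries 1-carboxyethyl in place of 3-hydroxy-1-(hydroxymethyl)propyl on an amide-type nitrogen. Going by the values given here, the only measured step, a 1.5-fold lower number from compound 1 to compound 2 (0.17 log units; within the scatter), puts hydroxymethyl in place of hydrogen and stays within the scatter. It offers no direct measure of a 1-carboxyethyl group, so the expectation stays loose. The expected change is a 1.1-fold higher number from compound 2 to compound 3 (0.02 log units; within the scatter), which is none beyond the scatter. For compound 3 the estimated value in this assay is 30000 nM, with an expected range of 10000 nM to 80000 nM.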

Compound 3, half-maximal inhibitory concentration: 35500 nM
Compound 3: middle estimate off by 1.2-fold (0.07 log units), on the low side; low and high end bracket the measured number.
By their numbers in this assay, from the lowest: compounds 2, 3 and 1 (each within the scatter of the next).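

On the amide-type nitrogen, 1-carboxyethyl stays within the scatter of both 3-hydroxy-1-(hydroxymethyl)propyl (a 1.2-fold higher number from compound 2 to compound 3 (0.10 log units; within the scatter)) and 3-hydroxypropyl (a 1.2-fold lower number from compound 1 to compound 3 (0.07 log units; within the scatter)) in this assay. This position thus now carries a chain ending in a carboxylic acid as well as the two alcohol chains, with no difference that can be read among compounds 1, 2 and 3. No measurement is at hand that would explain this result.

Still open, on these data alone, is whether an amine or a longer chain on this nitrogen would move the number beyond the scatter. As far as these compounds go, the mirror-image form of the 1-carboxyethyl group also remains open.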